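Prenyloxy to propargyloxy on the chalcone core

This account rests on a few compounds, and the source may have more. Where it says the series, first, only, none or still open, it means among the compounds named here.

In an ADME assay on Vero cells (Chlorocebus sabaeus) for cytotoxicity, read by resazurin assay, with a stated time of 72 h (on this read-out higher numbers stand for lower toxicity in this test and lower numbers for higher toxicity in this test), compound 1 `CC(C)=CCOc1ccc(C(=O)/C=C/c2cccnc2)c(O)c1` gives 210000 nM. This is the highest of the two numbers in hand; compound 2 `COc1cc(OCC=C(C)C)ccc1C(=O)/C=C/c1cccnc1` gives 22000 nM in this assay, and the step of a 9.5-fold lower number from compound 1 to compound 2 (0.98 log units; beyond the scatter) concerns methyl in place of hydrogen on an oxygen on an aromatic ring. Compound 3 `C#CCOc1ccc(C(=O)/C=C/c2cccnc2)c(O)c1` is not yet measured in this assay. It differs from compound 1 by ethynyl in place of 2-methylprop-1-en-1-yl on a saturated chain carbon bound to an oxygen on an aromatic ring, so the change lies on the ether chain and not on the free hydroxyl. Within the data shown here, no measured step touches that position; the one step known, from the methylation of the hydroxyl, has no bearing on an exchange of the ether chain. Compound 3 is therefore expected to stay close to compound 1, with a step of a 1.3-fold lower number from compound 1 to compound 3 (0.12 log units; within the scatter) not beyond the scatter. For compound 3 the estimate in this assay is 160000 nM, with a range from 45000 nM to 450000 nM.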

Compound 3, half-maximal cytotoxic concentration: 40000 nM
Compound 3: middle estimate off by 4.0-fold (0.60 log units), on the high side; measured number below the stated range.
By their numbers in this assay, from the lowest: compounds 2 and 3 (each within the scatter of the next); then compound 1.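

The ether chain is not a silent position in this assay: ethynyl in place of 2-methylprop-1-en-1-yl gives a 5.3-fold lower number from compound 1 to compound 3 (0.72 log units; beyond the scatter) and so moves the read-out towards higher toxicity in this test. Among these compounds, until now the only measured step was a 9.5-fold lower number from compound 1 to compound 2 (0.98 log units; beyond the scatter) on the hydroxyl, so the ether chain is a second place on the core of compound 1 where a single change moves the number beyond the scatter. Nothing in hand accounts for the size or direction of this step.

On these data alone, whether the drop follows the shorter chain or the triple bond stays open, and a saturated chain such as butyl or a benzyl group as the ether would help separate the two. Also open, as far as these compounds go, is how propargyloxy behaves when the hydroxyl carries a methyl group.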